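The source may hold more compounds than are shown below. What is called first, only, known or untested is meant among the compounds shown, and "the series" means these compounds.

Compound 1 `CCCCCCOC[C@@H]1C2CCC(O2)[C@H]1C/C=C\CCCC(=O)O`: 25000 nM; 18000 nM; 500 nM (3 entries)
Compound 2 `CCCCCCOC[C@@H]1C2CCC(O2)[C@@H]1C/C=C\CCCC(=O)O`: 38500 nM; 10000 nM (2 entries)
Compound 3 `CCCCCCCCOCC1C2CCC(O2)C1C/C=C\CCCC(=O)O`: 32000 nM

All three compounds were tested in a functional assay (plasma) for inhibition, with Homo sapiens as the target; a lower number here means a stronger inhibitor, a higher number a weaker inhibitor. Going by the values given here, compound 3, at 32000 nM, is the only one with a single number. Compound 1 and compound 2 each have several entries that lie far apart, so compound 3 cannot be given a firm rank against them.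

Compound 4 `O=C(O)CCC/C=C\CC1C2CCC(O2)C1COCCCc1ccccc1` has not yet been measured. It differs from compound 3 as follows: phenyl in place of pentyl on a saturated chain carbon, three bonds along the chain from an oxygen on a saturated carbon. This places phenyl in place of pentyl on a saturated chain carbon, three bonds along the chain from an oxygen on a saturated carbon, which turns octyl into 3-phenylpropyl. Among the compounds with values here, no measured step shows the effect of such a change in this assay, so no step beyond the usual scatter is expected, with only a slight lean towards stronger inhibition. The estimate means an expected 1.6-fold lower number from compound 3 to compound 4 (0.20 log units; within the scatter). The range is kept wide because compound 1 gives 25000 nM; 18000 nM; 500 nM (3 entries). For compound 4 the estimated value is 20000 nM, with an expected range of 5000 nM to 60000 nM.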

Compound 4, half-maximal inhibitory concentration: 26000 nM
Beside the measured number, compound 4's estimate is 1.3-fold (0.11 log units) below it, within the range that was stated.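

In this assay, the position three bonds along the chain from an oxygen on a saturated carbon now has its first readable step: phenyl in place of pentyl, which turns octyl into 3-phenylpropyl, gives a 1.2-fold lower number from compound 3 to compound 4 (0.09 log units; within the scatter). Going by these compounds alone, a six-membered aromatic ring of carbon only can thus stand at this place on the chain with the number staying within the scatter, which the earlier compounds, all with open chains here, could not show. Nothing given here accounts for the size of this step.

The compounds shown leave open whether a chlorophenyl, a methoxyphenyl or a pyridine ring at this place would move the number beyond the scatter. They also leave open how a benzyl or phenethyl group would read in this position.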